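This account rests on a few compounds, and the source may have more. Where it says the series, first, only, none or still open, it means among the compounds named here.

Working notes on the series. The shared core is carried by compound 1 `COc1cc2c(cc1OC)C(CC(=O)O)CC2`, which in a functional assay on the whole organism (strain Wistar) for inhibition, with Rattus norvegicus as the target, read by paw edema, with stated times of 60 min and 4 h, at a dose of 100 mg/kg by the oral route (a lower number here means less inhibition, a higher number more inhibition at the dose given (going by the name of the read-out)), gives 23.9%. Compound 2 `COc1cc2c(cc1OC)C(CC(=O)NC1CCCC1)CC2` gives 45.3% in this assay, and compound 3 `COc1cc2c(cc1OC)C(CC(=O)N1CCCCC1)CC2` gives 32%. On these three numbers compound 3 stands second highest: its nearest neighbour is compound 1, the gap being within the scatter, and its furthest is compound 2, the gap being beyond the scatter. The step of a number 8.1 percentage points higher from compound 1 to compound 3 (within the scatter) is within the scatter, whereas a number 13.3 percentage points lower from compound 2 to compound 3 (beyond the scatter) is a modest step beyond it, and a number 21.4 percentage points higher from compound 1 to compound 2 (beyond the scatter) is likewise modest.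

Compound 4 `COc1cc2c(cc1OC)C(CC(=O)N1CCNCC1)CC2` is not yet measured. The change from compound 3 is piperazin-1-yl in place of piperidin-1-yl on a carbonyl carbon. For the measured compounds named here, none of the measured steps changes a ring member within a group on the carbonyl carbon; the two steps that bear on it, a number 8.1 percentage points higher from compound 1 to compound 3 (within the scatter) and a number 13.3 percentage points lower from compound 2 to compound 3 (beyond the scatter), show that exchanging the whole group on that carbonyl carbon moves the number only modestly or not at all. A step no larger than that is expected here, in no definite direction, and most likely one within the scatter: no change at the digits printed from compound 3 to compound 4 (within the scatter) is the expected step. Compound 4 is therefore estimated at 32%, with a range from 14% to 50%.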

Compound 4, a percentage reported as inhibition, in the whole organism at one dose (the size of the read-out at that dose, not a potency): 40.6%
For compound 4 the middle estimate is 8.6 percentage points below the measured one; the measured number falls inside the stated range.
By their numbers in this assay, from the lowest: compounds 1, 3, 4 and 2 (each within the scatter of the next, the first and the last beyond it).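

For the compounds shown here, this is the first change of a single ring member within the group on the carbonyl carbon, and with piperazin-1-yl in place of piperidin-1-yl, a number 8.6 percentage points higher from compound 3 to compound 4 (within the scatter) in this assay, so the extra ring nitrogen and its hydrogen do not separate the two amides at this resolution. It also shows that a six-membered ring on the carbonyl carbon can stand clear of the hydroxy compound, with a number 16.7 percentage points higher from compound 1 to compound 4 (beyond the scatter), which the step from the acid to the piperidin-1-yl amide did not show, while a number 4.7 percentage points lower from compound 2 to compound 4 (within the scatter) leaves the piperazin-1-yl and cyclopentylamino amides unresolved, so compound 4 falls within the scatter of both compound 2 and compound 3, although those two lie beyond the scatter of each other. No measurement here bears on why the numbers fall as they do.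

The compounds shown leave open whether morpholin-4-yl or 4-methylpiperazin-1-yl on the same carbonyl carbon would fit with these amides or move the number further, and whether a longer chain between the shared core and the carbonyl would matter. Going by these compounds, with every number read at one dose, the order of compounds 2, 3 and 4 remains unsettled, and their relative potency remains unknown.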